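The source may hold more compounds than are shown below. What is called first, only, known or untested is meant among the compounds shown, and "the series" means these compounds.

Measured so far:
Compound 1, `C[C@]1(O)CC(=O)OC(CSc2nc(-c3ccccc3)c(-c3ccccc3)[nH]2)C1`, gives 140 nM in an assay on microsomes from liver for inhibition of sterol O-acyltransferase 1 (Rattus norvegicus); a higher number here means a weaker inhibitor, a lower number a stronger inhibitor.
Compound 2, `C[C@@]1(O)CC(=O)OC(CSc2nc(-c3ccc(Cl)cc3)c(-c3ccc(Cl)cc3)[nH]2)C1`, gives 180 nM in this assay.
Compound 3, `C[C@@]1(O)CC(=O)OC(CSc2nc(-c3ccccc3Cl)c(-c3ccccc3Cl)[nH]2)C1`, gives 140 nM in this assay.

In this assay compound 1 stands level with compound 3, and the number for compound 2 lies close by; the gaps among all three fall within the usual scatter, so no order among them can be read from these figures. The three share a core and differ only in the substitution of their two phenyl rings, which leaves the numbers essentially untouched.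

Compound 4, `c1ccc(-c2nc(SCC3OCCCO3)[nH]c2-c2ccccc2)cc1`, keeps the unsubstituted phenyl rings of compound 1 but alters the other side of the molecule: a group of 6 heavy atoms (4 carbon, 2 oxygen; one six-membered non-aromatic ring with 2 hetero atoms) in place of a group of 9 heavy atoms (6 carbon, 3 oxygen; one six-membered non-aromatic ring with 1 hetero atom), on a saturated chain carbon bound to a sulfur. Within the data shown here, the hydrogen-bond donor and the lactone carbonyl of that side are thereby lost, and no measured pair shows what this exchange does. Since the group that changes is the one kept constant across all three measured compounds, the step from compound 1 to compound 4 is expected to weaken inhibition moderately, a 3.6-fold higher number from compound 1 to compound 4 (0.55 log units; beyond the scatter). Compound 4 is therefore estimated at 500 nM, most likely between 150 nM and 2000 nM.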

Compound 4, half-maximal inhibitory concentration: 180 nM
The estimate for compound 4 lay 2.8-fold (0.44 log units) above the measured number; the range from low to high includes it.
By their numbers in this assay, from the lowest: compounds 1, 3, 2 and 4 (each within the scatter of the next).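

Until now all the compounds carried the same group on the saturated chain carbon bound to a sulfur, so nothing showed how this assay responds to a change there. Replacing the group of 9 heavy atoms with the smaller group of 6 heavy atoms gives a 1.3-fold higher number from compound 1 to compound 4 (0.11 log units; within the scatter), so for this pair, the hydrogen-bond donor and the double bond outside aromatic rings that leave with the larger group are not required for a number in this range. Nothing available explains why the two groups give such similar numbers.

The compounds shown leave open whether another group at this place, such as an amine, a carboxylic acid or a longer carbon chain, would move the number beyond the scatter. Also open, as far as these compounds go, is how the chlorine-bearing phenyl rings of compound 2 and compound 3 would behave alongside the group of 6 heavy atoms.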